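Shifting the Fluorine on the Benzyl Group

A few compounds are considered here, and "the series" means these few. Any claim that something is new, unique, unknown or untested is made for them only; others in the source may bear on it.

Measured so far in an assay for binding affinity to Alpha-1B adrenergic receptor (Homo sapiens); a higher number here means a weaker inhibitor, a lower number a stronger inhibitor: compound 1 `CN1CCC[C@@H]1Cn1nc(Cc2ccc(O)cc2)c2ccccc2c1=O` gives 398 nM; compound 2 `CN1CCC[C@@H]1Cn1nc(Cc2ccc(F)c(F)c2)c2ccccc2c1=O` gives 316 nM; compound 3 `CN1CCC[C@@H]1Cn1nc(Cc2ccc(F)cc2)c2ccccc2c1=O` gives 79.4 nM.

Compound 3 has the lowest number of the three and is the strongest binder shown, since both a 5.0-fold lower number from compound 1 to compound 3 (0.70 log units; beyond the scatter) and a 4.0-fold lower number from compound 2 to compound 3 (0.60 log units; beyond the scatter) lie beyond the scatter. The step of a 1.3-fold lower number from compound 1 to compound 2 (0.10 log units; within the scatter) is within the scatter, so compounds 1 and 2 cannot be separated.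

Compound 4 `CN1CCC[C@@H]1Cn1nc(Cc2cccc(F)c2)c2ccccc2c1=O` is not yet measured. It differs from compound 3 in one place: 3-fluorophenyl in place of 4-fluorophenyl on a saturated chain carbon bound to an aromatic carbon. For the measured compounds named here, no measured pair makes exactly this change, so the expectation is pieced together. Compound 2 carries both the fluoro of compound 3 and the fluoro of compound 4, and the step of a 4.0-fold lower number from compound 2 to compound 3 (0.60 log units; beyond the scatter) shows that dropping the fluoro compound 4 keeps gave a modest gain. The gain in a 5.0-fold lower number from compound 1 to compound 3 (0.70 log units; beyond the scatter) came with the 4-fluorophenyl that compound 4 gives up. So compound 4 is expected to give a modestly higher number in this assay than compound 3, likely landing near compound 2 and possibly within the scatter of either.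

Compound 4 is therefore estimated at 200 nM, with a range of 70 nM to 600 nM. That corresponds to an expected step of a 2.5-fold higher number from compound 3 to compound 4 (0.40 log units; beyond the scatter).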

Compound 4, inhibition constant: 398 nM
Beside the measured number, compound 4's estimate is 2.0-fold (0.30 log units) below it; measured number inside the range.
By their numbers in this assay, from the lowest: compound 3; then compounds 2, 1 and 4 (each within the scatter of the next).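

In this assay, moving the single fluoro from the 4-fluorobenzyl to the 3-fluorobenzyl arrangement gives a clear loss (a 5.0-fold higher number from compound 3 to compound 4 (0.70 log units; beyond the scatter)), even though the two groups have the same atoms, so what matters here is where the fluoro sits and not only that it is present. Compound 4 also cannot be separated from the difluoro compound (a 1.3-fold higher number from compound 2 to compound 4 (0.10 log units; within the scatter)) or from the hydroxy compound (no change at the digits printed from compound 1 to compound 4 (within the scatter)). For the compounds shown here, of the four compounds, only the single fluoro of compound 3 stands apart, and the 3-fluorophenyl group offers no gain over the other two groups.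

As far as these compounds go, whether chloro, methyl or methoxy in the place of that fluoro would match compound 3 remains open. Nothing measured here explains why the position of the fluoro matters.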